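The compounds below may be only part of what the source reports. "The series", "measured", "known", "first", "only" and "open" are said of these compounds alone.

Measured so far: compound 1 `O=C(Nc1cc(C(F)(F)F)ccc1Nc1ccc(Br)cc1)c1ccncc1`, "not active" (no number reported); compound 2 `O=C(Nc1cc(C(F)(F)F)ccc1NC1CCCCC1)c1ccncc1`, 80900 nM.

In a functional assay on Jurkat cells (Homo sapiens) for cytotoxicity, read by MTT assay, with a stated time of 48 h (a lower number here means a stronger inhibitor, a higher number a weaker inhibitor), compound 1 is recorded as "not active" (no number reported), so no single number places it on a scale. Compound 2, in this assay, gives 80900 nM. Compound 3 `O=C(Nc1cc(C(F)(F)F)ccc1Nc1ccc(Br)cc1)c1cccnc1` differs from compound 1 only by pyridin-3-yl in place of pyridin-4-yl on a carbonyl carbon. Going by the values given here, no measured pair shows a step of this kind, and compound 1 gives no number to start from, so a shift beyond the scatter in this assay is not expected in either direction. Compound 3 is therefore expected to give about 100000 nM in this assay, within 20000 nM to 500000 nM, with a fair chance that only a limit is reported.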

Compound 3, half-maximal inhibitory concentration: 17800 nM
Beside the measured number, compound 3's estimate is 5.6-fold (0.75 log units) above it, outside the stated range (below it).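

In this assay compound 1 stands as "not active" (no number reported) and compound 3 gives 17800 nM, so no step can be read between them. Nothing given here bears on this result. The compounds shown leave open how much pyridin-3-yl in place of pyridin-4-yl shifts the value in this assay.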